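Swapping fluoro for chloro on compound 3

A few compounds are considered here, and "the series" means these few. Any claim that something is new, unique, unknown or untested is made for them only; others in the source may bear on it.

Compound 1 `COc1ccc(SCc2ccc(C(=O)Nc3ccccc3N)cc2)cc1`: 81.8%
Compound 2 `Nc1ccccc1NC(=O)c1ccc(CSc2cccc(F)c2)cc1`: 76.3%
Compound 3 `Nc1ccccc1NC(=O)c1ccc(CSc2ccc(F)cc2)cc1`: 54.3%

In a functional assay on A-375 cells (Homo sapiens) for inhibition, read by CCK-8 assay, with a stated time of 72 h, tested at 8 uM (on this read-out lower numbers stand for less inhibition of growth and higher numbers for more inhibition of growth at the one concentration tested), compound 3 gives 54.3%, the lowest of the three numbers. Compound 4 `Nc1ccccc1NC(=O)c1ccc(CSc2ccc(Cl)cc2)cc1` differs from it in a single substituent, with chloro in place of fluoro on an aromatic carbon.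

Going by the values given here, no measured compound carries chloro, so the evidence is indirect. Among the compounds with values here, two measured steps touch this same ring. Replacing methoxy with fluoro gives a number 27.5 percentage points lower from compound 1 to compound 3 (beyond the scatter). Shifting the fluoro gives a number 22 percentage points lower from compound 2 to compound 3 (beyond the scatter). Small edits on this ring have therefore moved the number by a modest amount. With compound 3 at the bottom of the series, a rise of a similar or smaller size seems more likely than a further fall, although a change within the scatter cannot be ruled out.

The expected step is a number 11.7 percentage points higher from compound 3 to compound 4 (beyond the scatter).

Compound 4 is therefore estimated at 66%, with an expected range of 50% to 82%.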

Compound 4, percent growth inhibition at one concentration: 48.6%
The estimate for compound 4 lay 17.4 percentage points above the measured number; the whole stated range lies above it.
By their numbers in this assay, from the lowest: compounds 4 and 3 (each within the scatter of the next); then compounds 2 and 1 (each within the scatter of the next).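

In this assay, chloro in place of fluoro on the aromatic carbon para to a large group gives a number 5.7 percentage points lower from compound 3 to compound 4 (within the scatter), so these two halogens cannot be told apart at this place. The low number of compound 3 is therefore not particular to fluoro: the chloro compound also falls short of the methoxy compound, with a number 33.2 percentage points lower from compound 1 to compound 4 (beyond the scatter), and of the compound with its fluoro on a different ring carbon, with a number 27.7 percentage points lower from compound 2 to compound 4 (beyond the scatter). Nothing available explains these differences.

Going by these compounds, it remains open whether an amine or a carboxylic acid at this place would stay with the two halogens or come closer to methoxy. On these data alone, it is also open whether ethoxy, a longer chain than methoxy, would keep the higher number of compound 1.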